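The source may report more compounds than this note shows. Statements on the series, on what has been measured and on what is new or still open speak of the compounds shown alone.

Measured so far:
- Compound 1 `COc1ccc(-c2c(-c3cc(OC)c(OC)c(OC)c3)noc2N)cc1`: 12000 nM
- Compound 2 `COc1ccc(-c2c(-c3cc(OC)c(OC)c(OC)c3)noc2N)cc1OC`: > 50000 nM (a limit)

Among the compounds with values here, in a functional assay on SMMC-7721 cells (Homo sapiens) for cytotoxicity, read by MTT assay, with a stated time of 48 h (a higher number here means a weaker inhibitor, a lower number a stronger inhibitor), compound 1 gives 12000 nM, the only actual number so far. The result for compound 2 is a limit, > 50000 nM.

Compound 3 `COc1cc(-c2noc(N)c2-c2ccc(Cl)cc2)cc(OC)c1OC` differs from compound 1 by chloro in place of methoxy on an aromatic carbon, with chloro in place of methoxy on an aromatic carbon. Within the data shown here, the one measured step, an at least 4.1-fold higher number from compound 1 to compound 2 (0.61 log units; beyond the scatter), adds a methoxy rather than replacing one, so it is only a loose guide. It shows that compound 1 can lose strength with a single change, but it gives no firm direction here. The expected step is a 1.3-fold higher number from compound 1 to compound 3 (0.10 log units; within the scatter), which is none beyond the scatter. Compound 3 is estimated at 15000 nM, with an expected range of 4000 nM to 50000 nM.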

Compound 3, half-maximal inhibitory concentration: > 50000 nM
Compound 3: a limit, no number; the forecaster's own chance of this, stated with the estimate: 20%; middle value at least 3.3-fold (0.52 log units) away from the limit.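

In this assay, the change from 4-methoxyphenyl to 4-chlorophenyl gives an at least 4.1-fold higher number from compound 1 to compound 3 (0.61 log units; beyond the scatter), so chloro at this place does not keep the strength of compound 1. Earlier, only adding a methoxy, in compound 2, had shown a loss on this ring; replacing the existing methoxy now shows one too. The result for compound 3 is a limit and not a number, so the full size of this step stays unknown: the limit of > 50000 nM in this assay, at which 2 of the 3 values shown sit.

From the compounds shown here alone, what a hydroxyl, a methyl or an amine at this place would do remains open.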